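Phenyl Added on a Carbon Bound to Sulfur

A few compounds are considered here, and "the series" means these few. Any claim that something is new, unique, unknown or untested is made for them only; others in the source may bear on it.

Compound 1 `CSc1nc2c(C)nsc2n1[C@@H]1O[C@H](CO)[C@@H](O)[C@@H]1O` gives > 100000 nM in a functional assay on KB cells (Homo sapiens) for antiproliferative activity (a higher number here means a weaker inhibitor, a lower number a stronger inhibitor), which is a limit of the assay and not a number.
Compound 2 `Cc1nsc2c1nc(SCc1ccccc1)n2[C@@H]1O[C@H](CO)[C@@H](O)[C@@H]1O` gives > 100000 nM in this assay, again a limit rather than a number.
Compound 3 `CSc1nc2c(C)nsc2n1[C@@H]1O[C@H](CO)[C@@H](O)[C@H]1O` gives > 100000 nM in this assay, also a limit.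

Compound 2 differs from compound 1 by phenyl in place of hydrogen on a saturated chain carbon bound to a sulfur. The step that the two limits leave unreadable from compound 1 to compound 2 cannot be sized because of the limit of > 100000 nM in this assay, at which 3 of the 3 values shown sit. The two cores, that of compound 1 and that of compound 3, differ by the two compounds have the same atoms and bonds and differ only in configuration as drawn: 1 of 4 stereo elements differ; a stereocentre at a saturated ring carbon is drawn S in compound 1 and R in compound 3. Here too a step that the two limits leave unreadable from compound 1 to compound 3 cannot be sized because of the limit of > 100000 nM in this assay, at which 3 of the 3 values shown sit, although the pair is a clean comparison, given (the fact that compounds 1 and 3 differ only in the configuration as drawn).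

Compound 4 `Cc1nsc2c1nc(SCc1ccccc1)n2[C@@H]1O[C@H](CO)[C@@H](O)[C@H]1O` has not yet been measured in this assay. It differs from compound 3 by phenyl in place of hydrogen on a saturated chain carbon bound to a sulfur, the same change that turned compound 1 into compound 2, at the same place. Set beside a step that the two limits leave unreadable from compound 1 to compound 2, the expected step is a number no higher from compound 3 to compound 4 (the limit leaves the size open), which is to say no readable movement. That expectation rests on compound 2, whose result > 100000 nM is a limit. It rests equally on compound 3, whose result > 100000 nM is a limit. Nothing among these three compounds reaches a measurable number, so the fourth is expected to behave the same way. Compound 4 is therefore estimated at 100000 nM, with a range from 30000 nM to 300000 nM, and most likely reported only as a limit.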

Compound 4, half-maximal inhibitory concentration: > 100000 nM
Compound 4 gave a limit, no number; the forecaster's own chance of this, stated with the estimate: 85%; the middle value lies on the limit itself.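

Compound 4 also stops at a limit of the assay, so its steps from compound 3 and from compound 2 cannot be read, and the same holds for every comparison among the four compounds: the limit of > 100000 nM in this assay, at which 4 of the 4 values shown sit.

The compounds shown leave open whether going from methylsulfanyl to benzylsulfanyl, or changing the configuration as drawn, shifts the result in this assay at all.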